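The source may report more compounds than this note shows. Statements on the series, on what has been measured and on what is new or still open speak of the compounds shown alone.

Compound 1, `Cc1cc(C)c(N2CCN(c3ncccn3)CC2)nn1`: in a functional assay on BV-2 cells (Mus musculus) for inhibition, read by ELISA, with a stated time of 16 h (on this read-out lower numbers stand for stronger inhibition and higher numbers for weaker inhibition), compound 1 reaches only the limit > 100000 nM.
Compound 2, `Cc1cc(-c2ccc(F)cc2)nnc1N1CCN(c2ncccn2)CC1`: in this assay compound 2 gives 76300 nM.
Compound 3, `Cc1cc(-c2cccnc2)nnc1N1CCN(c2ncccn2)CC1`: not yet measured in this assay.

For the measured compounds named here, compound 2 holds the only number reported in this assay; the other value shown is a limit, as the limit of > 100000 nM in this assay, at which 1 of the 2 values shown sits, records. Going by the values given here, the single measured step, an at least 1.3-fold lower number from compound 1 to compound 2 (0.11 log units; that floor lies within the scatter), put 4-fluorophenyl in place of methyl on an aromatic carbon, and its floor lies within the scatter, so it says little about direction or size. Compound 3 differs from compound 2 by pyridin-3-yl in place of 4-fluorophenyl on an aromatic carbon. Among the compounds with values here, no measured step concerns the exchange of one six-membered aromatic ring for another, so nothing in the data supports expecting a change beyond the scatter in this assay. The value of compound 2 also leaves room for compound 3 to return to the limit. The expected step is a 1.0-fold higher number from compound 2 to compound 3 (0.02 log units; within the scatter), which stays within the scatter. Compound 3 is expected to give 80000 nM, within a range from 25000 nM to 300000 nM, with a fair chance that only a limit is reported.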

Compound 3, half-maximal inhibitory concentration: > 100000 nM
Compound 3: a limit, no number; the forecaster's own chance of this, stated with the estimate: 40%; at least 1.2-fold (0.09 log units) between middle value and limit.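

Placing pyridin-3-yl on this carbon varies the aromatic group itself for the first time, and in this assay the exchange gives an at least 1.3-fold higher number from compound 2 to compound 3 (0.11 log units; that floor lies within the scatter), so the data do not establish that the 4-fluorophenyl group is any better or worse than pyridin-3-yl here. Compound 3 records only a limit, not a number, so a six-membered aromatic ring at this place does not by itself guarantee a measurable value. The step between compound 1 and compound 3 cannot be read, and compound 2 remains the only compound with a number, while the others sit at a single limit: the limit of > 100000 nM in this assay, at which 2 of the 3 values shown sit.

The compounds shown leave open whether the value of compound 2 reflects a real preference for a ring of carbon only or for its fluorine, or merely lies close to the limit. Going by these compounds, it also remains open whether a carboxylic acid or an amine on the aromatic ring, or a longer chain on this carbon, would bring a number clearly beyond the scatter.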